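Tetrahydroquinoline anilides: cytotoxicity against breast cancer cells

The compounds below may be only part of what the source reports. "The series", "measured", "known", "first", "only" and "open" are said of these compounds alone.

Measured compounds:
compound 1 `CC(=O)N1c2ccccc2CCC1C(=O)Nc1ccccc1O` — 89600 nM
compound 2 `O=C(Nc1ccccc1O)C1CCc2ccccc2N1C(=O)c1ccc(Cl)cc1` — 19600 nM
compound 3 `O=C(Nc1ccccc1C(F)(F)F)C1CCc2ccccc2N1` — 45500 nM

In a functional assay on MDA-MB-231 cells (Homo sapiens) for cytotoxicity, read by sulforhodamine B assay, with a stated time of 72 h (on this read-out higher numbers stand for weaker inhibition of growth and lower numbers for stronger inhibition of growth), compound 3 stands second highest of the three numbers, within the scatter of compound 1 and beyond the scatter from compound 2. Compound 4 `O=C(Nc1ccccc1O)C1CCc2ccccc2N1` differs from compound 3 by hydroxy in place of trifluoromethyl on an aromatic carbon, ortho to a large group. Among the compounds with values here, the only measured step, a 4.6-fold lower number from compound 1 to compound 2 (0.66 log units; beyond the scatter), concerns the group on the carbonyl carbon, not the anilide ring, so nothing measured bears on this change. The expectation for compound 4 is therefore no step beyond the scatter, a 1.1-fold higher number from compound 3 to compound 4 (0.04 log units; within the scatter). Compound 4 is estimated at 50000 nM, with a range from 15000 nM to 160000 nM.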

Compound 4, concentration for 50% growth inhibition: 5260 nM
Compound 4: the middle estimate sits 9.5-fold (0.98 log units) above what was measured; the whole stated range lies above it.
By their numbers in this assay, from the lowest: compound 4; then compound 2; then compounds 3 and 1 (each within the scatter of the next).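

In this assay, the anilide ring substituent proves to matter: hydroxy in place of trifluoromethyl, on an aromatic carbon ortho to a large group, gives an 8.7-fold lower number from compound 3 to compound 4 (0.94 log units; beyond the scatter). With hydroxy held constant, hydrogen in place of (4-chlorophenyl)carbonyl on the nitrogen gives a 3.7-fold lower number from compound 2 to compound 4 (0.57 log units; beyond the scatter), and hydrogen in place of acetyl gives a 17-fold lower number from compound 1 to compound 4 (1.23 log units; beyond the scatter), so both acyl groups on that nitrogen go with higher numbers than hydrogen. No available evidence bears on what lies behind these steps.

Open, from the compounds shown here alone, is whether a methoxy or an amine on that aromatic carbon would track hydroxy or trifluoromethyl. Also open, going by these compounds, is whether the hydroxy step would hold with acetyl on the nitrogen.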